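Swapping the Aryl Group on the Amide Nitrogen

This account rests on a few compounds, and the source may have more. Where it says the series, first, only, none or still open, it means among the compounds named here.

Of the compounds shown here, three built on one shared core have been measured in a functional assay on HEK293 cells for agonist activity at D(4) dopamine receptor (Homo sapiens), read by FLIPR; on this read-out lower numbers stand for smaller maximal responses and higher numbers for larger maximal responses. Compound 1 `O=C(NCN1CCC(c2cccc[n+]2[O-])CC1)c1ccccc1` reaches 63% in this assay. Compound 2 `O=C(CN1CCC(c2cccc[n+]2[O-])CC1)Nc1cccc(F)c1` reaches 70%, and compound 3 `O=C(CN1CCC(c2cccc[n+]2[O-])CC1)Nc1cccc(Cl)c1Cl` reaches 66%. On these numbers compound 3 sits close to both others: its gap to compound 1 and its gap to compound 2 each lie within the usual scatter, so no order among the three can be read from them. Within the data shown here, only one step between compounds that differ in a single place is available, a number 4 percentage points lower from compound 2 to compound 3 (within the scatter), where 2,3-dichlorophenyl took the place of 3-fluorophenyl on an amide-type nitrogen.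

Compound 4 `Cc1ccc(Cl)cc1NC(=O)CN1CCC(c2cccc[n+]2[O-])CC1` differs from compound 3 by 5-chloro-2-methylphenyl in place of 2,3-dichlorophenyl on an amide-type nitrogen. Among the measured compounds shown here, the one step at hand bears on it directly, since it also exchanged the aromatic group on the amide-type nitrogen, and it stayed within the scatter. A step of similar size is therefore expected, a number 1 percentage points lower from compound 3 to compound 4 (within the scatter), with no change beyond the scatter in either direction. Compound 4 is estimated at 65%, within a range from 52% to 78%.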

Compound 4, largest response reached (reported as efficacy), in percent of the reference or control that the assay uses: 58%
For compound 4 the middle estimate is 7 percentage points above the measured one, within the range that was stated.
By their numbers in this assay, from the lowest: compounds 4, 1, 3 and 2 (each within the scatter of the next, the first and the last beyond it).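

Among these compounds, on the amide-type nitrogen, putting 5-chloro-2-methylphenyl in place of 3-fluorophenyl gives a number 12 percentage points lower from compound 2 to compound 4 (beyond the scatter) in this assay and is the first step here to clear the scatter, so the aryl group at this position can shift the maximal response modestly. Putting the same group in place of 2,3-dichlorophenyl gives a number 8 percentage points lower from compound 3 to compound 4 (within the scatter) and leaves compound 3 inseparable from compound 4, even though compound 4 is now separated from compound 2. No measurement at hand explains the difference between compound 2 and compound 4.

Which part of the 5-chloro-2-methylphenyl group goes with the lower number stays open, as the chlorine and the methyl enter together. Also open, on these data alone, is how the response would change with a methoxy group on this aryl ring or with a cyclohexyl ring in its place.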